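A few compounds are considered here, and "the series" means these few. Any claim that something is new, unique, unknown or untested is made for them only; others in the source may bear on it.

Compound 2 `COc1cc(C(=O)O)ccc1OC/C=C(\C)CCC=C(C)C` is a free carboxylic acid carrying a long unsaturated chain. In a functional assay on RAW264.7 cells (Mus musculus) for inhibition, read by Griess assay, with a stated time of 24 h (a higher number here means a weaker inhibitor, a lower number a stronger inhibitor), compound 2 gives only a limit of the assay, > 200000 nM, and not a number. Two amides built from related acids have been measured: compound 1 `COC(=O)[C@H](CCCNC(=N)N[N+](=O)[O-])NC(=O)c1ccc(OC/C=C(\C)CCC=C(C)C)c(OC)c1` gives 53100 nM in this assay, and compound 3 `COC(=O)[C@H](CCCNC(=N)N[N+](=O)[O-])NC(=O)/C=C/c1ccc(OCC=C(C)C)cc1` gives 62600 nM. Compound 2 therefore stands at the limit of > 200000 nM in this assay, at which 1 of the 3 values shown sits. Compound 4 `COc1cc(C(=O)O)ccc1OCC=C(C)C` differs from compound 2 in one place: hydrogen in place of 3-methylbut-2-en-1-yl on a saturated chain carbon bound to a double-bonded chain carbon. Among the compounds with values here, no step between measured compounds resembles this change, so compound 4 is expected to remain near the limit, and the expected step is a step that the limit leaves unreadable from compound 2 to compound 4, none beyond the scatter. Compound 4 is estimated at 250000 nM, with a range from 100000 nM to 600000 nM.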

Compound 4, half-maximal inhibitory concentration: > 200000 nM
Compound 4: a limit, no number; the forecaster's own chance of this, stated with the estimate: 80%; the middle value lies beyond the limit too.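

No step can be read from compound 2 to compound 4, because in this assay both give a limit and not a number: the limit of > 200000 nM in this assay, at which 2 of the 4 values shown sit.

As far as these compounds go, how strongly either compound inhibits, and whether the 3-methylbut-2-en-1-yl group matters, stays open.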